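The compounds below may be only part of what the source reports. "The series", "measured", "known", "first", "only" and "open" are said of these compounds alone.

Three compounds share one core and differ only in the aromatic group on a ring nitrogen. Compound 1 `Cc1cc(=O)n(-c2ccccc2C(F)(F)F)nc1C(=O)Nc1ccc(Oc2ncnc3ccsc23)c(F)c1` gives 9380 nM in a functional assay on HepG2 cells (Homo sapiens) for cytotoxicity, read by MTT assay, with a stated time of 72 h; on this read-out higher numbers stand for weaker inhibition and lower numbers for stronger inhibition. Compound 2 `Cc1ccc(-n2nc(C(=O)Nc3ccc(Oc4ncnc5ccsc45)c(F)c3)c(C)cc2=O)cc1` gives 17300 nM in this assay, and compound 3 `Cc1cc(=O)n(-c2ccc(F)c(F)c2)nc1C(=O)Nc1ccc(Oc2ncnc3ccsc23)c(F)c1` gives 6930 nM. The step of a 1.8-fold higher number from compound 1 to compound 2 (0.27 log units; within the scatter) and the step of a 1.4-fold lower number from compound 1 to compound 3 (0.13 log units; within the scatter) stay within the scatter, while the step of a 2.5-fold lower number from compound 2 to compound 3 (0.40 log units; beyond the scatter) is modest but real; compound 3 therefore holds the lowest number of the three, though it is not separated from compound 1 beyond the scatter.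

Compound 4 `Cc1cc(=O)n(-c2ccc(F)c(F)c2)nc1C(=O)Nc1ccc(Oc2ncnc3sccc23)c(F)c1` keeps the 3,4-difluorophenyl group of compound 3 and changes only the other end: a group of 9 heavy atoms (6 carbon, 2 nitrogen, 1 sulfur; one five-membered aromatic ring with 1 hetero atom, one six-membered aromatic ring with 2 hetero atoms) in place of a group of 9 heavy atoms (6 carbon, 2 nitrogen, 1 sulfur; one five-membered aromatic ring with 1 hetero atom, one six-membered aromatic ring with 2 hetero atoms), on an oxygen on an aromatic ring. Going by the values given here, no measured step touches this part of the molecule, so none of the three steps bears on the change directly. With nothing to point either way, no shift beyond the scatter is expected, and the step of a 1.0-fold lower number from compound 3 to compound 4 (0.00 log units; within the scatter) is estimated to be small. Compound 4 is therefore expected to give about 6900 nM, in a range from 3000 nM to 16000 nM.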

Compound 4, half-maximal inhibitory concentration: > 40000 nM
Compound 4 ended at the assay's limit (the forecaster's own chance of this, stated with the estimate: 5%); middle value at least 5.7-fold (0.76 log units) away from the limit.
By their numbers in this assay, from the lowest: compounds 3, 1 and 2 (each within the scatter of the next, the first and the last beyond it). At a limit, above all of these: compound 4.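

The two groups on an oxygen on an aromatic ring have the same atoms, joined differently, and the same rings and hydrogen-bond counts, yet in this assay there is an at least 5.7-fold higher number from compound 3 to compound 4 (0.76 log units; beyond the scatter). Going by these compounds alone, this end of the molecule, which no earlier step touched, therefore matters in this assay, and only this change reaches the limit, which compound 1, compound 2 and compound 3 did not. The reading for compound 4 is a limit and not a number, and the step rests on it: the limit of > 40000 nM in this assay, at which 1 of the 4 values shown sits.

The compounds shown do not tell why joining the same atoms differently has this effect, or whether it would also appear with the 4-methylphenyl or 2-(trifluoromethyl)phenyl group on the ring nitrogen. As far as these compounds go, how a plain phenyl ring or a chain carrying an amine would read on that oxygen also stays open.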